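Methyl on the Outer Ring in a Cytotoxicity Screen

A few compounds are considered here, and "the series" means these few. Any claim that something is new, unique, unknown or untested is made for them only; others in the source may bear on it.

Compound 1 `C/C(=C\c1cc(-c2ccccc2)co1)C(N)=O`: in an ADME assay on NIH3T3 cells (Mus musculus) for cytotoxicity, read by CCK-8 assay, with a stated time of 24 h (a lower number here means a stronger inhibitor, a higher number a weaker inhibitor), compound 1 gives > 50000 nM, which is a limit of the assay and not a number.
Compound 2 `C/C(=C\c1cc(-c2ccc(C)cc2)co1)C(N)=O`: in this assay compound 2 gives > 50000 nM, also a limit.
Compound 3 `C/C(=C\c1cccc(-c2ccccc2)c1)C(N)=O`: in this assay compound 3 gives > 50000 nM, again a limit.

Compound 2 differs from compound 1 by methyl in place of hydrogen on an aromatic carbon. The step that the two limits leave unreadable from compound 1 to compound 2 stays unreadable, since (the limit of > 50000 nM in this assay, at which 3 of the 3 values shown sit). The core of compound 3 differs from that of compound 1, and that difference is not broken down here. Compound 4 `C/C(=C\c1cccc(-c2ccc(C)cc2)c1)C(N)=O` is compound 3 with the same change, (methyl in place of hydrogen on an aromatic carbon).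

For compound 4 the expected outcome in this assay is 80000 nM. The expected step that the limit leaves unreadable from compound 3 to compound 4 rests on (the limit of > 50000 nM in this assay, at which 3 of the 3 values shown sit), so another limit is the likely report for compound 4.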

Compound 4, half-maximal inhibitory concentration: > 50000 nM
Compound 4 gave a limit, no number; the forecaster's own chance of this, stated with the estimate: 90%; the middle value lies beyond the limit too.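

Compound 3 and compound 4 both gave a limit of the assay and not a number, so no step between them can be read, because: the limit of > 50000 nM in this assay, at which 4 of the 4 values shown sit.

Going by these compounds, whether methyl in place of hydrogen changes the result in this assay on either core stays open.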